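Restoring a dimethylpyrazole on the core of compound 3

The source may report more compounds than this note shows. Statements on the series, on what has been measured and on what is new or still open speak of the compounds shown alone.

Three compounds sharing one core were tested in an assay on isolated protein for inhibition of Leucine-rich repeat serine/threonine-protein kinase 2 (Homo sapiens), read by TR-FRET and LanthaScreen, with stated times of 50 min and 30 min, in the presence of a further agent that is not named here; on this read-out higher numbers stand for weaker inhibition and lower numbers for stronger inhibition. Compound 1 `Cc1c(Nc2nc(N)c3c(C#N)c(N4CCC[C@H]4C)n(C)c3n2)cnn1C` gives 75 nM. Compound 2 `Cc1nn(C2CCOC2)cc1Nc1nc(N)c2c(C#N)c(N3CCC[C@H]3C)n(C)c2n1` gives 19 nM; 44 nM (2 entries). Compound 3 `C[C@@H]1CCCN1c1c(C#N)c2c(N)nc(N)nc2n1C` gives 248 nM, the highest of the two single numbers, with compound 1 the nearest to it. Among the compounds with values here, the only measured step of this kind, a 3.3-fold higher number from compound 1 to compound 3 (0.52 log units; beyond the scatter), removed a 1,5-dimethyl-1H-pyrazol-4-yl from the aromatic nitrogen. Compound 4 `Cc1nn(C)cc1Nc1nc(N)c2c(C#N)c(N3CCC[C@H]3C)n(C)c2n1` reverses that sort of change: 1,3-dimethyl-1H-pyrazol-4-yl in place of hydrogen on a nitrogen on an aromatic ring. Because the related removal produced a 3.3-fold higher number from compound 1 to compound 3 (0.52 log units; beyond the scatter), adding a closely similar dimethylpyrazole is expected to lower the number by about the same amount. Compound 4 is therefore expected to give 80 nM, within 25 nM to 250 nM. The expected step is a 3.1-fold lower number from compound 3 to compound 4 (0.49 log units; beyond the scatter).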

Compound 4, half-maximal inhibitory concentration: 38 nM
Compound 4: the middle estimate sits 2.1-fold (0.32 log units) above what was measured, and the stated range covers the measured number.
By their numbers in this assay, from the lowest: compounds 4 and 1 (each within the scatter of the next); then compound 3.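

The 1,3-dimethyl-1H-pyrazol-4-yl on this nitrogen brings a clear gain over the plain amino group (a 6.5-fold lower number from compound 3 to compound 4 (0.81 log units; beyond the scatter)), so the gain is not confined to the 1,5-dimethyl-1H-pyrazol-4-yl of compound 1. Exchanging one dimethylpyrazole for the other gives no readable difference (a 2.0-fold lower number from compound 1 to compound 4 (0.30 log units; within the scatter)), so the two arrangements of methyl groups cannot be ranked here. Repeat entries show how far a single compound can spread in this assay: the several entries of compound 2 in this assay, 19 nM; 44 nM (2 entries).

On these data alone, whether a group without a pyrazole, such as a phenyl ring or a simple methyl, would lower the number as well remains open.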